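Aryl swap at the saturated ring carbon: compound 4

This account rests on a few compounds, and the source may have more. Where it says the series, first, only, none or still open, it means among the compounds named here.

Measured in a functional assay on Ehrlich cells (Mus musculus) for antiproliferative activity, read by trypan blue exclusion, with a stated time of 2 h, tested at 10 ug/mL; on this read-out lower numbers stand for a weaker effect and higher numbers for a stronger effect at the one concentration tested:
compound 1 `N#CC1=C(N)N(c2ccc(S(N)(=O)=O)cc2)C2=C(C(=O)CCC2)C1c1cccc([N+](=O)[O-])c1` gives 42%
compound 2 `N#CC1=C(N)N(c2ccc(S(N)(=O)=O)cc2)C2=C(C(=O)CCC2)C1c1c(O)ccc2ccccc12` gives 0%
compound 3 `Cc1ccoc1C1C(C#N)=C(N)N(c2ccc(S(N)(=O)=O)cc2)C2=C1C(=O)CCC2` gives 2%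

Compound 3 is second highest of the three numbers; its nearest neighbour is compound 2, within the scatter, and its furthest is compound 1, beyond it. Compound 4 `N#CC1=C(N)N(c2ccc(S(N)(=O)=O)cc2)C2=C(C(=O)CCC2)C1c1cccs1` differs from compound 3 by thiophen-2-yl in place of 3-methylfuran-2-yl on a saturated ring carbon. Among the compounds with values here, the steps that bear on this place are a number 40 percentage points lower from compound 1 to compound 3 (beyond the scatter) and a number 2 percentage points higher from compound 2 to compound 3 (within the scatter); both aryl-for-nitrophenyl exchanges gave low numbers, and the two five-membered or fused groups sit together. A further five-membered ring change is therefore expected to give a number 3 percentage points higher from compound 3 to compound 4 (within the scatter) in this assay. The estimate for compound 4 is 5%, with a range from 0% to 25%.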

Compound 4, a percentage reported as activity, at one concentration (the size of the read-out at that concentration, not a potency): 70%
For compound 4 the middle estimate is 65 percentage points below the measured one; the measured number lies above the stated range.
By their numbers in this assay, from the lowest: compounds 2 and 3 (each within the scatter of the next); then compound 1; then compound 4.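

In this assay the group on the saturated ring carbon matters even between close relatives: the change gives a number 68 percentage points higher from compound 3 to compound 4 (beyond the scatter) although both groups are five-membered aromatic rings with 1 hetero atom. Thiophen-2-yl also stands clear of the other groups, with a number 70 percentage points higher from compound 2 to compound 4 (beyond the scatter) and a number 28 percentage points higher from compound 1 to compound 4 (beyond the scatter) so a five-membered ring here does not in itself go with a low number. Nothing available explains this gap.

The change swaps the ring hetero atom and removes the methyl at once, and the compounds shown do not separate the two. From the compounds shown here alone, whether furan-2-yl or 3-methylthiophen-2-yl would side with compound 3 or with compound 4 stays open.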